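Aryl substituent swaps on the shared urea-linked series

The source may report more compounds than this note shows. Statements on the series, on what has been measured and on what is new or still open speak of the compounds shown alone.

Three analogues of a common core have been measured in a functional assay on the whole organism for inhibition, with Mus musculus as the target, with a stated time of 1 h, at a dose of 100 mg/kg by the intraperitoneal route; on this read-out lower numbers stand for less inhibition and higher numbers for more inhibition at the one dose given (going by the name of the read-out). Compound 1 `Cc1ccccc1NC(=O)Nn1c(C)nc2ccccc2c1=O` gives 51% in this assay. Compound 2 `Cc1cccc(NC(=O)Nn2c(C)nc3ccccc3c2=O)c1` gives 51%, and compound 3 `Cc1nc2ccccc2c(=O)n1NC(=O)Nc1ccc(I)cc1` gives 53%. The step of no change at the digits printed from compound 1 to compound 2 (within the scatter) arises from 3-methylphenyl in place of 2-methylphenyl on an amide-type nitrogen; the steps of a number 2 percentage points higher from compound 1 to compound 3 (within the scatter) and a number 2 percentage points higher from compound 2 to compound 3 (within the scatter) arise from 4-iodophenyl in place of a methylphenyl on the same amide-type nitrogen. Compound 3 carries the highest of the three numbers, but its gaps to compound 1 and compound 2 both sit within the scatter, so no ordering can be read from them.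

Compound 4 `Cc1nc2ccccc2c(=O)n1NC(=O)Nc1ccc([N+](=O)[O-])cc1` differs from compound 3 by nitro in place of iodo on an aromatic carbon. All three measured steps bear on this change, since each also alters the group on the amide-type nitrogen, and none moved the read-out beyond the scatter. The expectation for compound 4 in this assay is therefore a step of a number 1 percentage points lower from compound 3 to compound 4 (within the scatter), with no shift beyond the scatter. Compound 4 is estimated at 52%, within the range 40% to 64%.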

Compound 4, a percentage reported as inhibition, in the whole organism at one dose (the size of the read-out at that dose, not a potency): 40%
For compound 4 the middle estimate is 12 percentage points above the measured one; the measured number falls inside the stated range.
By their numbers in this assay, from the lowest: compound 4; then compounds 1, 2 and 3 (each within the scatter of the next).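

Within the data shown here, this position on the aromatic ring is not indifferent in this assay: nitro in place of iodo gives a number 13 percentage points lower from compound 3 to compound 4 (beyond the scatter), the first step to pass beyond the scatter, whereas the earlier swaps among 2-methylphenyl, 3-methylphenyl and 4-iodophenyl all stayed within it. The flat picture from the first three compounds therefore does not extend to every group at this site, and the read-out can respond to a single substituent change on an otherwise unchanged structure. Nothing available explains this step, and the hydrogen-bond acceptors that enter with nitro remain only a counted difference.

Going by these compounds, whether the lower number is peculiar to nitro remains open, as a single pair cannot show it. An amine or a carboxylic acid on the same aromatic carbon would test how far the step extends.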